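The source may hold more compounds than are shown below. What is called first, only, known or untested is meant among the compounds shown, and "the series" means these compounds.

Compound 1 `CC(C)(N)C(=O)N[C@H](COCc1ccccc1)c1nnnn1CCCc1ccccc1` — 200 nM in an assay on isolated protein for displacement of a labelled ligand from growth hormone secretagogue receptor type 1 (Homo sapiens), with a stated time of 1 h; a lower number here means a stronger inhibitor, a higher number a weaker inhibitor
Compound 2 `CC(C)(N)C(=O)N[C@H](COCc1ccccc1)c1nnn(C/C=C/c2ccccc2)n1` — > 5000 nM in this assay, a limit of the assay rather than a number

Going by the values given here, compound 1 holds the only number given in this assay; for compound 2 the value is a limit, recorded as the limit of > 5000 nM in this assay, at which 1 of the 2 values shown sits. Compound 3 `CCCCNC(=O)CCCn1nnnc1[C@@H](COCc1ccccc1)NC(=O)C(C)(C)N` differs from compound 1 in one place: butylcarbamoyl in place of phenyl on a saturated chain carbon, three bonds along the chain from an aromatic nitrogen. Among the compounds with values here, with no measured step to lean on, the expected step from compound 1 to compound 3 is estimated as a 6.0-fold higher number from compound 1 to compound 3 (0.78 log units; beyond the scatter), a loss beyond the scatter. Compound 3 is therefore expected to give about 1200 nM in this assay, within a range of 300 nM to 5000 nM.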

Compound 3, inhibition constant: 1780 nM
Estimate against measurement, compound 3: 1.5-fold (0.17 log units) below; the measured number falls inside the stated range.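

Exchanging phenyl for butylcarbamoyl at this place on the chain weakens binding, with an 8.9-fold higher number from compound 1 to compound 3 (0.95 log units; beyond the scatter) in this assay, yet a measured number remains rather than a limit. An aromatic ring at the end of this chain is therefore not required for measurable binding, although phenyl gives the stronger of the two values. Nothing given here accounts for the size of this step. The compounds shown leave open whether the step follows from losing the phenyl ring or from gaining the amide: how a cyclohexyl, a plain hexyl chain or a benzylcarbamoyl group would read at this place remains open.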